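The source may report more compounds than this note shows. Statements on the series, on what has been measured and on what is new or still open speak of the compounds shown alone.

In an ADME assay on HUVEC cells (Homo sapiens) for cytotoxicity, read by MTT assay, with a stated time of 24 h (a lower number here means that less compound is tolerated, a higher number that more compound is tolerated), compound 1 (`Cc1ccc(/C=C/c2nnc(-c3ccc4c(c3)OCCO4)o2)cc1`) gives 265000 nM and compound 2 (`O=[N+]([O-])c1ccccc1/C=C/c1nnc(-c2ccc3c(c2)OCCO3)o1`) gives 323000 nM, so these two numbers lie within the usual scatter of each other. Compound 3 (`C(=C/c1nnc(-c2ccc3c(c2)OCCO3)o1)\c1ccccc1`) differs from compound 2 by one change: hydrogen in place of nitro on an aromatic carbon. For the measured compounds named here, no measured step yet shows the effect of such a change, so no shift beyond the scatter is expected in this assay. The expected step, a 1.2-fold lower number from compound 2 to compound 3 (0.06 log units; within the scatter), is correspondingly small. For compound 3 the estimated value is 280000 nM, within an expected range of 130000 nM to 600000 nM.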

Compound 3, half-maximal cytotoxic concentration: 209000 nM
Compound 3: middle estimate off by 1.3-fold (0.13 log units), on the high side; low and high end bracket the measured number.
By their numbers in this assay, from the lowest: compounds 3, 1 and 2 (each within the scatter of the next).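

In this assay, hydrogen in place of nitro on an aromatic carbon, ortho to a large group, gives a 1.5-fold lower number from compound 2 to compound 3 (0.19 log units; within the scatter) and dropping the methyl group gives a 1.3-fold lower number from compound 1 to compound 3 (0.10 log units; within the scatter). Compound 3, with neither group, thus stays within the scatter of both compound 1 and compound 2, so neither nitro nor methyl sets its compound apart from the hydrogen compound here. Nothing measured accounts for these numbers. Going by these compounds, whether an amine or a carboxylic acid on this ring would move the number beyond the scatter remains open.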